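Adding a methyl to the hydroxyethyl amide

The compounds below may be only part of what the source reports. "The series", "measured", "known", "first", "only" and "open" are said of these compounds alone.

Measured in a functional assay on PC-3 cells (Homo sapiens) for antiproliferative activity, read by MTT assay, with a stated time of 24 h; on this read-out lower numbers stand for stronger inhibition and higher numbers for weaker inhibition:
- compound 1 `CCn1c(C(=O)N[C@@H](CC(=O)OC)C(=O)OC)ccc1C(CC)(CC)c1ccc(OCS(=O)(=O)c2ccccc2)c(C)c1`: 6490 nM
- compound 2 `CCn1c(C(=O)N[C@@H](C)CO)ccc1C(CC)(CC)c1ccc(OCS(=O)(=O)c2ccccc2)c(C)c1`: 9520 nM
- compound 3 `CCn1c(C(=O)NCCO)ccc1C(CC)(CC)c1ccc(OCS(=O)(=O)c2ccccc2)c(C)c1`: 17700 nM

Compound 3 sits within the scatter of compound 2, as shown by a 1.9-fold higher number from compound 2 to compound 3 (0.27 log units; within the scatter). It lies beyond the scatter on the weaker side of compound 1, as shown by a 2.7-fold higher number from compound 1 to compound 3 (0.44 log units; beyond the scatter).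

Compound 4 `CCn1c(C(=O)N[C@H](C)CO)ccc1C(CC)(CC)c1ccc(OCS(=O)(=O)c2ccccc2)c(C)c1` is reached from compound 3 by putting methyl in place of hydrogen on a saturated chain carbon bound to an amide-type nitrogen and a saturated chain carbon.

The most relevant measured step is the one that replaces this methyl with hydrogen: a 1.9-fold higher number from compound 2 to compound 3 (0.27 log units; within the scatter). Compound 2 also carries 1-(hydroxymethyl)ethyl, and it gives 9520 nM. The steps from the 1,2-bis(methoxycarbonyl)ethyl amide, a 1.5-fold higher number from compound 1 to compound 2 (0.17 log units; within the scatter) and a 2.7-fold higher number from compound 1 to compound 3 (0.44 log units; beyond the scatter), involve a different change and bear on this one only weakly.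

A slightly lower number is therefore expected in this assay, with no shift beyond the scatter. The expected step is a 1.6-fold lower number from compound 3 to compound 4 (0.21 log units; within the scatter). For compound 4 the estimate is 11000 nM, with an expected range of 6000 nM to 20000 nM.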

Compound 4, half-maximal inhibitory concentration: 7790 nM
Beside the measured number, compound 4's estimate is 1.4-fold (0.15 log units) above it, within the range that was stated.
By their numbers in this assay, from the lowest: compounds 1, 4, 2 and 3 (each within the scatter of the next, the first and the last beyond it).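

In this assay, methyl in place of hydrogen on this saturated chain carbon gives a step beyond the scatter with one drawn configuration, a 2.3-fold lower number from compound 3 to compound 4 (0.36 log units; beyond the scatter), while the other configuration stays within it, a 1.9-fold higher number from compound 2 to compound 3 (0.27 log units; within the scatter). That contrast is not a real stereochemical preference, since the direct comparison of the two methyl compounds stays within the scatter, a 1.2-fold lower number from compound 2 to compound 4 (0.09 log units; within the scatter), and this pair isolates a single element: the fact that compounds 2 and 4 differ only in the configuration as drawn. The 1-(hydroxymethyl)ethyl amide with this configuration also cannot be separated from the 1,2-bis(methoxycarbonyl)ethyl amide, a 1.2-fold higher number from compound 1 to compound 4 (0.08 log units; within the scatter).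

Still open, from the compounds shown here alone, is what a longer chain, such as ethyl, would do in place of the methyl on this carbon. Also open, going by these compounds, is whether an amine or a carboxylic acid could take the place of the hydroxyl at the chain end.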